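The source may report more compounds than this note shows. Statements on the series, on what has been measured and on what is new or still open speak of the compounds shown alone.

Measured so far:
compound 1, `c1ccc(Oc2ncnc3[nH]cnc23)cc1`, 16%
compound 2, `Fc1ccc(Oc2[nH]cnc3ncnc2-3)cc1`, 9%
compound 3, `Cn1cnc2c(Nc3ccccc3)ncnc21`, 0%

In an assay on isolated protein for inhibition of Rho-associated protein kinase 1 (Homo sapiens), tested at 30 uM (on this read-out lower numbers stand for less inhibition and higher numbers for more inhibition at the one concentration tested (going by the name of the read-out)), compound 3 gives 0%, the lowest of the three numbers. Its nearest neighbour is compound 2, whose value of 9% lies within the usual scatter of this kind of measurement, so no order between these two can be claimed. The value of compound 1, 16%, stands beyond the scatter from compound 3. Among the compounds with values here, compound 1 and compound 2 differ in more than one place, so their two values show only that compound 1 sits higher; no single change can be held to account for it.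

Compound 4, `Cn1cnc2c(Nc3ccc(F)cc3)ncnc21`, is the next compound to be measured. It differs from compound 3 in one place: fluoro in place of hydrogen on an aromatic carbon. Within the data shown here, no comparable step between two measured compounds is available, so the expectation for compound 4 rests on compound 3 alone, whose value of 0% lies at the bottom of the range. The step of a number 3 percentage points higher from compound 3 to compound 4 (within the scatter) is expected to stay within the scatter. Compound 4 is therefore estimated at about 3% in this assay, in a range from -5% to 12%.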

Compound 4, a percentage reported as inhibition, at one concentration (the size of the read-out at that concentration, not a potency): 7%
The estimate for compound 4 lay 4 percentage points below the measured number; the measured number falls inside the stated range.
By their numbers in this assay, from the lowest: compounds 3, 4, 2 and 1 (each within the scatter of the next, the first and the last beyond it).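

In this assay, within the data shown here, the step of a number 7 percentage points higher from compound 3 to compound 4 (within the scatter) is the first that isolates a single change, fluoro in place of hydrogen on an aromatic carbon of a six-membered aromatic ring of carbon only, para to a large group. Since that step stays within the scatter, this read-out cannot separate the two compounds, and at this position the swap of one hydrogen for one fluorine has no effect that can be claimed at the one concentration tested. No independent measurement bears on this result, so the step stands as an observation without an explanation.

The compounds shown leave open whether a larger or different group at the same position, such as a methoxy group, an amine, a carboxylic acid or a longer alkyl chain, would carry the number beyond the scatter from compound 3. They also leave open whether fluoro on another carbon of the same ring would read any differently, since this single step speaks for one place and one small group only.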